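This account rests on a few compounds, and the source may have more. Where it says the series, first, only, none or still open, it means among the compounds named here.

Compound 1 `O=C1/C(=C/c2coc3ccccc3c2=O)N=C(c2ccccc2)N1c1ccc(S(=O)(=O)Nc2ncccn2)cc1` was tested in a functional assay on A549 cells (Homo sapiens) for cytotoxicity, read by sulforhodamine B assay, with a stated time of 72 h (on this read-out higher numbers stand for weaker inhibition and lower numbers for stronger inhibition), where compound 1 gives 40500 nM. Compound 2 `CCOC1Oc2ccccc2C(=O)/C1=C/Nc1ccc(S(=O)(=O)Nc2cc(C)on2)cc1` gives 57200 nM in this assay, a number that sits within the scatter of the number for compound 1, so the two cannot be told apart. Compound 3 `CCOC1Oc2ccccc2C(=O)/C1=C/Nc1ccc(S(=O)(=O)Nc2ncccn2)cc1` reaches only a limit of the assay, > 100000 nM, the limit described by the limit of > 100000 nM in this assay, at which 1 of the 3 values shown sits. Among the compounds with values here, the one measured step, an at least 1.7-fold higher number from compound 2 to compound 3 (0.24 log units; that floor lies within the scatter), changes the group on the sulfonamide nitrogen, and its floor lies within the scatter.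

Compound 4 `O=C1/C(=C/c2coc3ccccc3c2=O)N=C(c2ccccc2)N1c1ccc(S(=O)(=O)Nc2ccccn2)cc1` differs from compound 1 by pyridin-2-yl in place of pyrimidin-2-yl on a sulfonamide nitrogen. Within the data shown here, this change also sits on the sulfonamide nitrogen, but no measured pair shows this exact swap, and the one step that changes the substituent on that nitrogen did not clearly move the number beyond the scatter. A step of no clear size beyond the scatter is therefore expected, a 1.1-fold lower number from compound 1 to compound 4 (0.03 log units; within the scatter). Compound 4 is expected to give 38000 nM in this assay, between 13000 nM and 100000 nM.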

Compound 4, half-maximal inhibitory concentration: > 100000 nM
Compound 4: only a limit was reported (the forecaster's own chance of this, stated with the estimate: 15%); middle value at least 2.6-fold (0.42 log units) away from the limit.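

On the core of compound 1, the group on the sulfonamide nitrogen clearly matters in this assay: the swap gives an at least 2.4-fold higher number from compound 1 to compound 4 (0.39 log units; beyond the scatter), whereas the earlier step at this nitrogen, an at least 1.7-fold higher number from compound 2 to compound 3 (0.24 log units; that floor lies within the scatter), had a floor that could not be told from the scatter. The change is small, since pyridin-2-yl holds one ring nitrogen where pyrimidin-2-yl holds two, so exchanging a single ring atom at this place is enough to move the number. The value of compound 4 is a limit of the assay and not a number, so the true size of the step stays unknown: the limit of > 100000 nM in this assay, at which 2 of the 4 values shown sit.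

Going by these compounds, whether the same swap moves the number on the core of compound 2 remains open. So does how a simple acetyl group on this nitrogen, or a pyrimidin-2-yl ring carrying an amine, would read.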